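The compounds below may be only part of what the source reports. "The series", "measured", "known", "first", "only" and "open" are said of these compounds alone.

Compound 3, with the structure `Fc1ccc(C2=NNC(c3cn(-c4ccccc4)nc3-c3ccc(Cl)c(Cl)c3)C2)cc1`, carries only a hydrogen on the ring nitrogen that the other two compounds decorate. In a functional assay on the whole organism (strain Wistar) for inhibition, with Rattus norvegicus as the target, read by paw edema, with stated times of 30 min and 120 min, at a dose of 50 mg/kg by the oral route (a lower number here means less inhibition, a higher number more inhibition at the dose given (going by the name of the read-out)), compound 3 gives 46.1%. Compound 1, with the structure `Fc1ccc(C2=NN(c3ccccc3)C(c3cn(-c4ccccc4)nc3-c3ccc(Cl)c(Cl)c3)C2)cc1`, gives 60.2%, and compound 2, with the structure `CC(=O)N1N=C(c2ccc(F)cc2)CC1c1cn(-c2ccccc2)nc1-c1ccc(Cl)c(Cl)c1`, gives 72.7%. Compound 3 therefore stands lowest of the three numbers, the steps of a number 14.1 percentage points lower from compound 1 to compound 3 (beyond the scatter) and a number 26.6 percentage points lower from compound 2 to compound 3 (beyond the scatter) both running downward to it and both beyond the scatter.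

Compound 4, with the structure `O=[N+]([O-])c1ccc(N2N=C(c3ccc(F)cc3)CC2c2cn(-c3ccccc3)nc2-c2ccc(Cl)c(Cl)c2)cc1`, differs from compound 3 by the change (4-nitrophenyl in place of hydrogen on an amine nitrogen in a ring). Going by the values given here, the steps that bear on it are those in which the same nitrogen gains or loses a group: a number 14.1 percentage points lower from compound 1 to compound 3 (beyond the scatter) shows that removing a phenyl lowered the reading, and a number 26.6 percentage points lower from compound 2 to compound 3 (beyond the scatter) shows that removing an acetyl lowered it further. Read in reverse, placing a group on this nitrogen raised the number by a modest amount each time. A 4-nitrophenyl is another such group, so a modest rise beyond the scatter is expected for compound 4, of about a number 16.9 percentage points higher from compound 3 to compound 4 (beyond the scatter). Compound 4 is accordingly estimated to give 63%, in a range from 50% to 76%.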

Compound 4, a percentage reported as inhibition, in the whole organism at one dose (the size of the read-out at that dose, not a potency): 65.6%
The estimate for compound 4 lay 2.6 percentage points below the measured number, within the range that was stated.
By their numbers in this assay, from the lowest: compound 3; then compounds 1, 4 and 2 (each within the scatter of the next, the first and the last beyond it).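

A third group on this amine nitrogen in the ring again separates from hydrogen, with 4-nitrophenyl giving a number 19.5 percentage points higher from compound 3 to compound 4 (beyond the scatter) in this assay, so phenyl, acetyl and now 4-nitrophenyl all read above the unsubstituted compound 3. The new compound adds no clear gain over the earlier substituted compounds: the nitro on the aromatic carbon gives a number 5.4 percentage points higher from compound 1 to compound 4 (within the scatter) and the exchange of acetyl for 4-nitrophenyl gives a number 7.1 percentage points lower from compound 2 to compound 4 (within the scatter) as its reading, so the aryl and acyl groups cannot be ranked through this compound, even though compound 1 and compound 2 themselves differ beyond the scatter. Nothing measured here explains why a group on this nitrogen goes with a higher reading.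

Going by these compounds, what a methyl or a longer acyl chain such as propionyl would give on this nitrogen remains open, as does a phenyl carrying an amine or a carboxylic acid in place of the nitro. The compounds also leave open whether these differences would hold at other oral doses, since each reading comes from a single dose.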